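The source may report more compounds than this note shows. Statements on the series, on what has been measured and on what is new or still open speak of the compounds shown alone.

Compound 1 `O=C(/C=C/c1cnc(N2CCN(S(=O)(=O)c3ccc(OC(F)(F)F)cc3)CC2)s1)NO`: 6000 nM
Compound 2 `O=C(/C=C/c1cnc(N2CCN(S(=O)(=O)c3ccc(C(F)(F)F)cc3)CC2)s1)NO`: 3000 nM

Both compounds were tested in a functional assay on MCF7 cells (Homo sapiens) for antiproliferative activity; a lower number here means a stronger inhibitor of growth, a higher number a weaker inhibitor of growth. Compound 2 holds the lowest of the two numbers, with compound 1 its nearest neighbour, and the step of a 2.0-fold lower number from compound 1 to compound 2 (0.30 log units; within the scatter) lies within the scatter, so the two cannot be ranked against each other.

Compound 3 `O=C(/C=C/c1cnc(N2CCN(S(=O)(=O)c3ccc([N+](=O)[O-])cc3)CC2)s1)NO` differs from compound 2 by nitro in place of trifluoromethyl on an aromatic carbon. For the measured compounds named here, only one measured step bears on this change: a 2.0-fold lower number from compound 1 to compound 2 (0.30 log units; within the scatter) also exchanged the group on that same aromatic carbon, and it stayed within the scatter. Going by the values given here, no step involving a nitro group has been measured, so the data give no ground for expecting a shift beyond the scatter in this assay in either direction. The expected step is no change at the digits printed from compound 2 to compound 3 (within the scatter). Compound 3 is therefore estimated at 3000 nM, with a range from 1000 nM to 9000 nM.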

Compound 3, concentration for 50% growth inhibition: 5000 nM
Compound 3: middle estimate off by 1.7-fold (0.22 log units), on the low side, and the stated range covers the measured number.
By their numbers in this assay, from the lowest: compounds 2, 3 and 1 (each within the scatter of the next).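

Placing a third kind of group on this aromatic carbon, para to a large group, still produces no separable change in this assay: nitro in place of trifluoromethyl gives a 1.7-fold higher number from compound 2 to compound 3 (0.22 log units; within the scatter), and nitro in place of trifluoromethoxy gives a 1.2-fold lower number from compound 1 to compound 3 (0.08 log units; within the scatter). Every exchange measured at this position now lies within the scatter, even though nitro carries 2 hydrogen-bond acceptors and trifluoromethyl carries 0, so compounds 1, 2 and 3 cannot be ranked against one another. Nothing measured here offers an explanation for this result.

As far as these compounds go, whether an amine, a carboxylic acid or a longer chain on this aromatic carbon would shift the number beyond the scatter remains open. Also open, from the compounds shown here alone, is whether any of these three groups would give the same result at another place on the six-membered ring.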